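This account rests on a few compounds, and the source may have more. Where it says the series, first, only, none or still open, it means among the compounds named here.

Three compounds share one core. Compound 1 `N#Cc1c(C2CCCCC2)nc(S)[nH]c1=O` carries a bare sulfur. In an assay on isolated protein for inhibition of Rap guanine nucleotide exchange factor 4 (Homo sapiens), read by fluorescence and cAMP accumulation (a lower number here means a stronger inhibitor, a higher number a weaker inhibitor), compound 1 gives only a limit, > 300000 nM. Compound 2 `N#Cc1c(C2CCCCC2)nc(SCc2ccccc2)[nH]c1=O` puts a benzyl on that sulfur; in this assay compound 2 gives 30500 nM, and the step of an at least 9.8-fold lower number from compound 1 to compound 2 (0.99 log units; beyond the scatter). Compound 3 `N#Cc1c(C2CCCCC2)nc(SCC(=O)O)[nH]c1=O` instead puts a carboxymethyl on the sulfur. Compound 3 gives only a limit in this assay, > 300000 nM. The step is an at least 9.8-fold higher number from compound 2 to compound 3 (0.99 log units; beyond the scatter). So compound 3 sits together with compound 1 at the limit of > 300000 nM in this assay, at which 2 of the 3 values shown sit, the weak end of what has been measured. Compound 4 `Cc1ccc(NC(=O)CSc2nc(C3CCCCC3)c(C#N)c(=O)[nH]2)cc1` differs from compound 3 by (4-methylphenyl)amino in place of hydroxy on a carbonyl carbon. This brings an aromatic ring back onto the side chain, which compound 2 has and compound 3 lacks. Of the measured steps, an at least 9.8-fold lower number from compound 1 to compound 2 (0.99 log units; beyond the scatter) and an at least 9.8-fold higher number from compound 2 to compound 3 (0.99 log units; beyond the scatter) bear on this change; both were at least modest. The number is therefore expected to fall, with the step of an at least 10-fold lower number from compound 3 to compound 4 (1.00 log units; beyond the scatter). Compound 4 is estimated at 30000 nM, within 5000 nM to 300000 nM.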

Compound 4, half-maximal inhibitory concentration: > 300000 nM
Compound 4 was reported as a limit (the forecaster's own chance of this, stated with the estimate: 25%); middle value at least 10-fold (1.00 log units) away from the limit.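

Compound 4 gives only a limit in this assay, > 300000 nM. Compound 3 is also a limit, so no step to compound 4 can be read, and compound 4 joins the weak end: the limit of > 300000 nM in this assay, at which 3 of the 4 values shown sit.

The compounds shown leave open whether (4-methylphenyl)amino in place of hydroxy changes the number at all.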